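Swapping the aryl group on the sulfonamide nitrogen

The compounds below may be only part of what the source reports. "The series", "measured", "known", "first", "only" and "open" are said of these compounds alone.

Measured so far:
- compound 1 `CCc1ccc(NS(=O)(=O)c2ccc(N3CCNC3=O)cc2)cc1`: 660 nM
- compound 2 `O=C1NCCN1c1ccc(S(=O)(=O)Nc2ccc(F)c(F)c2)cc1`: 350 nM
- compound 3 `Cc1cc(C)cc(NS(=O)(=O)c2ccc(N3CCNC3=O)cc2)c1`: 82 nM

All three share one core and differ only in the aromatic group attached to the sulfonamide nitrogen. In a functional assay on HT-29 cells (Homo sapiens) for antiproliferative activity, read by sulforhodamine B assay, with a stated time of 48 h (a higher number here means a weaker inhibitor, a lower number a stronger inhibitor), compound 3 gives the lowest number of the three, standing a 4.3-fold lower number from compound 2 to compound 3 (0.63 log units; beyond the scatter) and an 8.0-fold lower number from compound 1 to compound 3 (0.91 log units; beyond the scatter). Compound 1 and compound 2 lie close to each other, as a 1.9-fold lower number from compound 1 to compound 2 (0.28 log units; within the scatter) shows.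

Compound 4 `COc1ccc(NS(=O)(=O)c2ccc(N3CCNC3=O)cc2)cc1` is the next member of the series. The change from compound 3 to compound 4 is 4-methoxyphenyl in place of 3,5-dimethylphenyl on a sulfonamide nitrogen. The two steps that bear on it are the ones leading into compound 3, each an exchange of the aryl group at the same position, and each a modest gain in potency for compound 3. Moving away from 3,5-dimethylphenyl to a phenyl that carries one group, as compound 1 does with 4-ethylphenyl, is therefore expected to lose some of that gain. The expected step is a 4.9-fold higher number from compound 3 to compound 4 (0.69 log units; beyond the scatter), in the direction of a higher number. Compound 4 is estimated at 400 nM, with a likely range from 120 nM to 1500 nM.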

Compound 4, half-maximal inhibitory concentration: 800 nM
Compound 4: middle estimate off by 2.0-fold (0.30 log units), on the low side; the range from low to high includes it.
By their numbers in this assay, from the lowest: compound 3; then compounds 2, 1 and 4 (each within the scatter of the next, the first and the last beyond it).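

Placing 4-methoxyphenyl on the sulfonamide nitrogen in this assay gives a 9.8-fold higher number from compound 3 to compound 4 (0.99 log units; beyond the scatter), so 3,5-dimethylphenyl now stands apart from three other aryl groups, not just two. Methoxy and ethyl on the aromatic carbon cannot be told apart, with a 1.2-fold higher number from compound 1 to compound 4 (0.08 log units; within the scatter), whereas the exchange of 3,4-difluorophenyl for 4-methoxyphenyl gives a 2.3-fold higher number from compound 2 to compound 4 (0.36 log units; beyond the scatter), a gap that the earlier compounds could not show. No measurement here explains why these aryl groups differ.

As far as these compounds go, what remains open is whether the low number of compound 3 needs both methyl groups, which 3-methylphenyl would test, or would also hold for other groups in the same places, as in 3,5-dimethoxyphenyl or 3,5-dichlorophenyl. The compounds shown also say nothing about an amine or a carboxylic acid on this aryl ring.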